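The compounds below may be only part of what the source reports. "The series", "measured", "known", "first", "only" and "open" are said of these compounds alone.

In a functional assay on HT-1080 cells (Homo sapiens) for cytotoxicity, read by MTT assay, with a stated time of 72 h (a lower number here means a stronger inhibitor, a higher number a weaker inhibitor), three related compounds have been measured so far. Compound 1 `COc1cccc(/C=C2\CCC/C(=C\c3cccc(O)c3)C2=O)c1OC` gives 8500 nM, compound 2 `COc1cccc(/C=C2\CCC/C(=C\c3ccc(O)c(Cl)c3)C2=O)c1OC` gives 14300 nM, and compound 3 `COc1ccc(/C=C2\CCC/C(=C\c3ccc(Br)cc3)C2=O)cc1OC` gives 4300 nM. Compound 3 therefore has the lowest of the three numbers, although its gap to compound 1 lies within the usual scatter. Only its gap to compound 2 lies beyond the scatter.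

Compound 4 `COc1ccc(/C=C2\CCC/C(=C\c3cccc(Cl)c3Cl)C2=O)cc1OC` differs from compound 3 in one place: 2,3-dichlorophenyl stands in place of 4-bromophenyl on a double-bonded chain carbon bound to a double-bonded ring carbon (2,3-dichlorophenyl in place of 4-bromophenyl on a double-bonded chain carbon bound to a double-bonded ring carbon). Among the measured compounds shown here, no measured compound carries this group, so the evidence is thin. For the measured compounds named here, the one measured step at this kind of place is a 1.7-fold higher number from compound 1 to compound 2 (0.23 log units; within the scatter), and it involves different groups on a different core. That small step gives no reason to expect a large shift in this assay, so no change beyond the scatter is expected, in either direction. The estimated step is a 1.2-fold higher number from compound 3 to compound 4 (0.07 log units; within the scatter). Compound 4 is expected at about 5000 nM, with an estimated range from 2000 nM to 13000 nM.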

Compound 4, half-maximal inhibitory concentration: 8800 nM
The estimate for compound 4 lay 1.8-fold (0.25 log units) below the measured number; measured number inside the range.
By their numbers in this assay, from the lowest: compounds 3, 1, 4 and 2 (each within the scatter of the next, the first and the last beyond it).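

In this assay, putting 2,3-dichlorophenyl in place of 4-bromophenyl on a double-bonded chain carbon bound to a double-bonded ring carbon gives a 2.0-fold higher number from compound 3 to compound 4 (0.31 log units; beyond the scatter). This modest step shows that a change at this kind of place can move the number beyond the scatter, which the earlier step, a 1.7-fold higher number from compound 1 to compound 2 (0.23 log units; within the scatter), on a different core did not show. Neither group carries a hydrogen-bond donor, a hydrogen-bond acceptor or a net charge, and nothing available explains the step.

This single swap changes the halogen and the number of halogens together, so the compounds shown cannot separate those two changes. On these data alone, it also remains open how this position would respond to a phenyl ring carrying an amine or a carboxylic acid.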